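Methoxy in place of fluoro at compound 3

The source may report more compounds than this note shows. Statements on the series, on what has been measured and on what is new or still open speak of the compounds shown alone.

In a functional assay on the whole organism with Mus musculus as the target (a higher number here means that more compound is needed for the effect, a lower number that less compound is needed), compound 1 (`Cn1nc(-c2ccc(F)cc2F)n(C)c1=S`) gives 1 mg/kg as its dose for half-maximal effect, and compound 2 (`Cn1nc(-c2ccc(F)cc2)n(C)c1=S`) gives 0.61 mg/kg on the same read-out. Among the measured compounds shown here, compound 2 therefore stands within the scatter of compound 1, its only measured neighbour, and the two cannot be told apart. Compound 3 (`COc1ccc(-c2nn(C)c(=S)n2C)cc1`) carries methoxy in place of fluoro on an aromatic carbon of compound 2 (methoxy in place of fluoro on an aromatic carbon). For the measured compounds named here, only one measured step bears on this change, and only loosely (a 1.6-fold lower number from compound 1 to compound 2 (0.21 log units; within the scatter)). Going by the values given here, that step also removes a fluoro and stays within the scatter, but no measured compound carries methoxy. No step beyond the scatter is expected, though the uncertainty is wide. The estimated move is small (a 1.3-fold higher number from compound 2 to compound 3 (0.12 log units; within the scatter)). Compound 3 is estimated at 0.8 mg/kg in this assay (expected range 0.25 mg/kg to 2.5 mg/kg).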

Compound 3, dose for half-maximal effect: > 25 mg/kg
Compound 3: no number, only a limit (the forecaster's own chance of this, stated with the estimate: 5%); middle value at least 31-fold (1.49 log units) away from the limit.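

In this assay compound 3 gives > 25 mg/kg, which is a limit of the assay and not a number: the limit of > 25 mg/kg in this assay, at which 1 of the 3 values shown sits. Even so, the change reads as an at least 40-fold higher number from compound 2 to compound 3 (1.61 log units; beyond the scatter), so this place, on an aromatic carbon para to a group of 8 heavy atoms, is far from indifferent to what it carries. Among the compounds shown here, the only earlier step, a 1.6-fold lower number from compound 1 to compound 2 (0.21 log units; within the scatter), took away the other fluoro, stayed within the scatter and gave no sign of such sensitivity.

The compounds shown leave open how far the number for compound 3 really lies from that of compound 2. They also leave open whether the oxygen or the added carbon of methoxy matters, which hydroxy, methyl, chloro or a plain hydrogen at this place could begin to separate.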